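Carbonyl substituent exchange on the shared core: cytotoxicity notes

The source may report more compounds than this note shows. Statements on the series, on what has been measured and on what is new or still open speak of the compounds shown alone.

Compound 1 `COc1cc(C(=O)C2Sc3nnc(-c4cc(OC)c(OC)c(OC)c4)n3NC2c2ccco2)cc(OC)c1OC` carries 3,4,5-trimethoxyphenyl on a carbonyl carbon. In a functional assay on HepG2 cells (Homo sapiens) for cytotoxicity, read by MTT assay, with a stated time of 48 h (a lower number here means a stronger inhibitor, a higher number a weaker inhibitor), compound 1 reaches only the limit > 100000 nM. Compound 2 `COc1cc(-c2nnc3n2NC(c2ccco2)C(C(=O)c2ccc(F)cc2)S3)cc(OC)c1OC` likewise gives in this assay the limit > 100000 nM. Compound 3 `COc1cc(-c2nnc3n2NC(c2ccco2)C(C(=O)C2CC2)S3)cc(OC)c1OC` gives in this assay the limit > 100000 nM. Hence a step that the two limits leave unreadable from compound 1 to compound 2, a step that the two limits leave unreadable from compound 1 to compound 3 and a step that the two limits leave unreadable from compound 2 to compound 3 cannot be read, since (the limit of > 100000 nM in this assay, at which 3 of the 3 values shown sit). Compound 4 `COc1cc(-c2nnc3n2NC(c2ccco2)C(C(=O)c2ccc(F)c(F)c2)S3)cc(OC)c1OC` differs from compound 1 by 3,4-difluorophenyl in place of 3,4,5-trimethoxyphenyl on a carbonyl carbon. The measured steps, all exchanges at the same carbonyl carbon, bear directly on this change but give no readable size in any direction. No step beyond the scatter is expected in this assay, and compound 4 is expected to sit at the limit as well. Estimated for compound 4: 100000 nM with range 50000 nM to 300000 nM, which would mean a number no higher from compound 1 to compound 4 (the limit leaves the size open).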

Compound 4, half-maximal inhibitory concentration: 52400 nM
For compound 4 the middle estimate is 1.9-fold (0.28 log units) above the measured one; the measured number falls inside the stated range.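

Among the compounds shown, only compound 4 gives a number rather than a limit in this assay, so exchange at this carbonyl carbon now has a readable floor: an at least 1.9-fold lower number from compound 1 to compound 4 (0.28 log units; that floor lies within the scatter), an at least 1.9-fold lower number from compound 3 to compound 4 (0.28 log units; that floor lies within the scatter) and an at least 1.9-fold lower number from compound 2 to compound 4 (0.28 log units; that floor lies within the scatter). Each floor stays within the scatter, so no real gain is shown, for the added fluoro or for the other two exchanges. The steps among compound 1, compound 2 and compound 3 still cannot be read: the limit of > 100000 nM in this assay, at which 3 of the 4 values shown sit.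

From the compounds shown here alone, the true size of these steps remains open. Also open, going by these compounds, is whether an amine or a carboxylic acid on the carbonyl carbon would give a step beyond the scatter.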